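Ortho substituent survey on the biphenyl octylsulfonamide acid series

A few compounds are considered here, and "the series" means these few. Any claim that something is new, unique, unknown or untested is made for them only; others in the source may bear on it.

Measured so far:
compound 1 `CCCCCCCCS(=O)(=O)Nc1ccc(-c2ccccc2Cl)cc1C(=O)O`: 14400 nM
compound 2 `CCCCCCCCS(=O)(=O)Nc1ccc(-c2ccccc2-c2ccccc2)cc1C(=O)O`: 10100 nM
compound 3 `CCCCCCCCS(=O)(=O)Nc1ccc(-c2ccccc2OC)cc1C(=O)O`: 27600 nM

All three values come from an assay on mitochondria (strain BALB/c) for inhibition of glycerol-3-phosphate acyltransferase 1, mitochondrial (Mus musculus), read by scintillation counting, with a stated time of 10 min; on this read-out higher numbers stand for weaker inhibition and lower numbers for stronger inhibition. Compound 3 has the highest number of the three. Its nearest neighbour is compound 1, the step of a 1.9-fold higher number from compound 1 to compound 3 (0.28 log units; within the scatter); the other neighbour is compound 2, the step of a 2.7-fold higher number from compound 2 to compound 3 (0.44 log units; beyond the scatter). The step of a 1.4-fold lower number from compound 1 to compound 2 (0.15 log units; within the scatter) is also small.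

Compound 4 `CCCCCCCCS(=O)(=O)Nc1ccc(-c2ccccc2F)cc1C(=O)O` differs from compound 3 in one place: fluoro in place of methoxy on an aromatic carbon. Among the compounds with values here, no measured pair exchanges methoxy for fluoro, so the nearest guide is the exchange of methoxy for another halogen, the reverse of the step from compound 1 to compound 3, which stayed within the scatter. The ortho position has so far tolerated chloro, phenyl and methoxy with only modest movement in this assay, so a small change in the number is expected, if any, in the direction of compound 1.

For compound 4 the expected step is a 1.7-fold lower number from compound 3 to compound 4 (0.24 log units; within the scatter). The estimate for compound 4 in this assay is 16000 nM, with a range from 7000 nM to 36000 nM.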

Compound 4, half-maximal inhibitory concentration: 34600 nM
For compound 4 the middle estimate is 2.2-fold (0.33 log units) below the measured one; the range from low to high includes it.
By their numbers in this assay, from the lowest: compounds 2, 1, 3 and 4 (each within the scatter of the next, the first and the last beyond it).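

In this assay the exchange of methoxy for fluoro at this position, ortho to a large group, gives no change that can be told from the scatter (a 1.3-fold higher number from compound 3 to compound 4 (0.10 log units; within the scatter)), so compound 3 and compound 4 cannot be separated despite the loss of the oxygen and of one hydrogen-bond acceptor. The exchange between the two halogens does separate, though only modestly (a 2.4-fold higher number from compound 1 to compound 4 (0.38 log units; beyond the scatter)), which shows that chloro and fluoro are not interchangeable here, whereas chloro and methoxy could not be separated. The exchange of phenyl for fluoro is the widest step in the set (a 3.4-fold higher number from compound 2 to compound 4 (0.53 log units; beyond the scatter)) but is still modest, so all four groups stay within a narrow span at this position.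

As far as these compounds go, whether a hydroxyl, an amine, a nitrile or a carboxylic acid at this position would leave the number within that span, or move it well outside, remains open, as does whether the same exchanges behave alike with a shorter chain in place of the octyl chain. No measurement shown bears on what lies behind these differences.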